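Iodo Replaces Furan-2-yl on a Nucleoside Scaffold

A few compounds are considered here, and "the series" means these few. Any claim that something is new, unique, unknown or untested is made for them only; others in the source may bear on it.

Measured compounds:
compound 1, `COc1ncnc2c1c(I)cn2[C@@H]1O[C@H](CO)[C@@H](O)[C@H]1O`: > 20000 nM
compound 2, `CNc1ncnc2c1c(-c1ccco1)cn2[C@@H]1O[C@H](CO)[C@@H](O)[C@H]1O`: 850 nM

Within the data shown here, in a functional assay on HepG2 cells (Homo sapiens) for antiproliferative activity, read by XTT assay, with a stated time of 72 h (a higher number here means a weaker inhibitor, a lower number a stronger inhibitor), compound 2 gives 850 nM, the only number reported among the two measured compounds. Compound 1 gives > 20000 nM in this assay, which is a limit of the assay and not a number; it sits at the limit of > 20000 nM in this assay, at which 1 of the 2 values shown sits. Among the measured compounds shown here, no step between measured compounds that differ in one place is available, since compound 1 and compound 2 differ in two places, so the two values show only that compound 2 reaches a number where compound 1 does not.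

Compound 3, `CNc1ncnc2c1c(I)cn2[C@@H]1O[C@H](CO)[C@@H](O)[C@H]1O`, is not yet measured in this assay. It differs from compound 2 by iodo in place of furan-2-yl on an aromatic carbon. Compound 3 shares the iodo group with compound 1 and the methylamino group with compound 2. With compound 1 at a limit, the step is expected to run toward weaker inhibition, beyond the scatter, as a 5.9-fold higher number from compound 2 to compound 3 (0.77 log units; beyond the scatter). Compound 3 is therefore estimated at 5000 nM, with a range from 1500 nM to 20000 nM.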

Compound 3, half-maximal inhibitory concentration: > 20000 nM
Compound 3: no number, only a limit; the forecaster's own chance of this, stated with the estimate: 35%; middle value at least 4.0-fold (0.60 log units) away from the limit.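

The earlier pair differed in two places, so it could not separate the group on the aromatic carbon from the other change, but with the methylamino group held constant that group now stands alone: in this assay, iodo in place of furan-2-yl gives an at least 23-fold higher number from compound 2 to compound 3 (1.37 log units; beyond the scatter). At this place, two ring bonds from the ring nitrogen, the change is therefore enough on its own to take the series from a measured number to a limit, and the methylamino group does not bring a number back when iodo is present. The step between the two iodo compounds cannot be read, and the step from the furan-2-yl compound is a minimum, not a full size: the limit of > 20000 nM in this assay, at which 2 of the 3 values shown sit.

Among these compounds, what the methylamino group adds over methoxy remains open, as no pair with a readable number at both ends isolates that change. It is also unknown whether the activity is particular to furan-2-yl or would persist with another ring at this carbon, such as thiophen-2-yl or phenyl, or with a small non-ring group such as an amine.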